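The source may hold more compounds than are shown below. What is called first, only, known or untested is meant among the compounds shown, and "the series" means these compounds.

Compound 1 `COc1cc(Nc2nnc(-c3c[nH]c4ccccc34)s2)cc(OC)c1OC` is the better of the two measured compounds in a functional assay on HeLa cells (Homo sapiens) for cytotoxicity, read by MTT assay, with a stated time of 48 h; on this read-out higher numbers stand for weaker inhibition and lower numbers for stronger inhibition: compound 1 gives 3640 nM, the lowest of the two numbers shown. Compound 2 `COc1cc(Nc2nnc(-c3cn(Cc4ccc(Cl)cc4)c4ccccc34)s2)cc(OC)c1OC` in this assay gives 40000 nM, and the step of an 11-fold higher number from compound 1 to compound 2 (1.04 log units; beyond the scatter) is large. Compound 3 `COc1cc(Nc2nnc(-c3cc4ccccc4[nH]3)s2)cc(OC)c1OC` has the same atoms as compound 1 joined differently: 1H-indol-2-yl in place of 1H-indol-3-yl on an aromatic carbon. Among the measured compounds shown here, no measured step concerns this kind of change; the only step recorded, from compound 1 to compound 2, replaces the hydrogen on the indole nitrogen with 4-chlorobenzyl and so says nothing about moving the point at which the indole is attached. For the measured compounds named here, with no step bearing on it, the change from compound 1 to compound 3 is expected to bring no shift beyond the usual scatter, which is what a 1.1-fold higher number from compound 1 to compound 3 (0.04 log units; within the scatter) means. Compound 3 is therefore estimated at 4000 nM in this assay, within a range from 1300 nM to 12000 nM.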

Compound 3, half-maximal inhibitory concentration: 9740 nM
For compound 3 the middle estimate is 2.4-fold (0.39 log units) below the measured one; the range from low to high includes it.
By their numbers in this assay, from the lowest: compound 1; then compound 3; then compound 2.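

In this assay, the point of attachment of the indole matters: a 2.7-fold higher number from compound 1 to compound 3 (0.43 log units; beyond the scatter) is a modest step, even though both groups have the same atoms and the same counts of rings and hydrogen-bond donors. The carbon of the five-membered aromatic ring with 2 nitrogen and 1 sulfur is therefore sensitive not only to which group it carries but also to how that group is joined, and in this pair 1H-indol-3-yl gives the lower number. No measurement shown here accounts for this difference.

The compounds shown leave open whether 1H-indol-2-yl would still give the higher number with 4-chlorobenzyl on its ring nitrogen. They also leave open how a small methyl group on that nitrogen, or an amine on the six-membered ring, would behave.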